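This account rests on a few compounds, and the source may have more. Where it says the series, first, only, none or still open, it means among the compounds named here.

Of the compounds shown here, three built on one shared core have been tested in a functional assay on the whole organism (strain Wistar) with Rattus norvegicus as the target, with a stated time of 5 min; a higher number here means that more compound is needed for the effect, a lower number that less compound is needed. Compound 1 `CCC1(CCCCN2CCN(c3ccc(C)c(Cl)c3)CC2)C(=O)Nc2ccccc21` reaches only a limit of the assay there, namely > 20 mg/kg. Compound 2 `CCC1(CCCCCN2CCN(c3cccc(Cl)c3)CC2)C(=O)Nc2ccccc21` likewise stops at a limit, > 10 mg/kg. Compound 3 `CCC1(CCCCN2CCN(c3ccc(Cl)cc3)CC2)C(=O)Nc2cc(F)ccc21` also gives only a limit, > 20 mg/kg. Compound 1 therefore stands without a number of its own: its value sits at the limit of > 20 mg/kg in this assay, at which 2 of the 3 values shown sit, while the remaining value sits at the limit of > 10 mg/kg in this assay, at which 1 of the 3 values shown sits, and none of the three compounds can be placed in order against another.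

Compound 4 `CCC1(CCCCN2CCN(c3cccc(OC)c3)CC2)C(=O)Nc2ccccc21` has not yet been tested in this assay. It differs from compound 1 in one place: 3-methoxyphenyl in place of 3-chloro-4-methylphenyl on an amine nitrogen in a ring. For the measured compounds named here, no step between two measured compounds is available to gauge such a change, so nothing in the data points to a shift in either direction beyond the scatter. The estimate for compound 4 is 20 mg/kg, with a range from 5 mg/kg to 60 mg/kg. The step expected is a number no higher from compound 1 to compound 4 (the limit leaves the size open). Most likely the assay will again report only a limit.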

Compound 4, minimum effective dose: > 20 mg/kg
Compound 4: a limit, no number (the forecaster's own chance of this, stated with the estimate: 70%); the middle value sits exactly at the limit.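

In this assay, for the compounds shown here, compound 1 and compound 4 both stop at a limit, so no step between them can be read: the limit of > 20 mg/kg in this assay, at which 3 of the 4 values shown sit.

The compounds shown leave open what dose any of them needs for the effect, and whether 3-methoxyphenyl in place of 3-chloro-4-methylphenyl changes that dose at all.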